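A Benzimidazolyl Group in Place of Benzyl on a Ring Nitrogen

The compounds below may be only part of what the source reports. "The series", "measured", "known", "first", "only" and "open" are said of these compounds alone.

Of the compounds shown here, three sharing one core have been measured in a functional assay on NCI-H460 cells (Homo sapiens) for antiproliferative activity, read by sulforhodamine B assay, with a stated time of 72 h; on this read-out lower numbers stand for stronger inhibition and higher numbers for weaker inhibition. Compound 1 `C#CCNCCN(C)CCNc1ccnc2cc(Cl)ccc12` gives 69000 nM, compound 2 `CN(CCNCc1cn(-c2ccc(Br)cc2)nn1)CCNc1ccnc2cc(Cl)ccc12` gives 15000 nM, and compound 3 `CN(CCNCc1cn(Cc2ccccc2)nn1)CCNc1ccnc2cc(Cl)ccc12` gives 32000 nM, the second highest of the three numbers, standing between the other two. Among the measured compounds shown here, the one measured step that bears on the coming change is a 2.1-fold higher number from compound 2 to compound 3 (0.33 log units; beyond the scatter), in which a group bound directly to the aromatic nitrogen was exchanged for a benzyl. Compound 4 `CN(CCNCc1cn(-c2nc3ccccc3[nH]2)nn1)CCNc1ccnc2cc(Cl)ccc12` turns that around: 1H-benzimidazol-2-yl in place of benzyl on an aromatic nitrogen, again placing an aromatic ring directly on the ring nitrogen. A modest downward step in this assay is therefore expected, roughly mirroring that earlier step, as a 2.1-fold lower number from compound 3 to compound 4 (0.33 log units; beyond the scatter). Compound 4 is estimated at 15000 nM, within a range from 5000 nM to 40000 nM.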

Compound 4, half-maximal inhibitory concentration: 33000 nM
Compound 4: the middle estimate sits 2.2-fold (0.34 log units) below what was measured; the measured number falls inside the stated range.
By their numbers in this assay, from the lowest: compound 2; then compounds 3 and 4 (each within the scatter of the next); then compound 1.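

In this assay, an aromatic ring set directly on the ring nitrogen does not by itself give the lower number seen with 4-bromophenyl: the change shows a 1.0-fold higher number from compound 3 to compound 4 (0.01 log units; within the scatter) and, against that group, a 2.2-fold higher number from compound 2 to compound 4 (0.34 log units; beyond the scatter). At this position, 1H-benzimidazol-2-yl and benzyl are therefore not told apart by this read-out, despite their different ring content. Nothing given here explains this result.

From the compounds shown here alone, it remains open whether plain phenyl or 4-methoxyphenyl on the same aromatic nitrogen would follow 4-bromophenyl or 1H-benzimidazol-2-yl. Going by these compounds, the effect of a methyl group on the benzimidazole ring nitrogen also remains open.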